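The compounds below may be only part of what the source reports. "The series", "measured", "known", "first", "only" and "open" are said of these compounds alone.

Measured so far in a functional assay on SW1573 cells (Homo sapiens) for inhibition, read by sulforhodamine B assay, with a stated time of 48 h; a lower number here means a stronger inhibitor of growth, a higher number a weaker inhibitor of growth:
- compound 1 `COC(=O)[C@@]1(C)CCC=C2[C@@H]1CC[C@@H](C)[C@]2(C)Cc1c[nH]c2ccccc12` gives 7300 nM
- compound 2 `COC(=O)[C@@]1(C)CCC=C2[C@@H]1CC[C@@H](C)[C@]2(C)Cc1c[nH]c2ccc(OC)cc12` gives 1300 nM
- compound 3 `COC(=O)[C@@]1(C)CCC=C2[C@@H]1CC[C@@H](C)[C@]2(C)Cc1c(C)[nH]c2ccccc12` gives 14000 nM

Compound 3 shows the highest number of the three. Its nearest neighbour is compound 1, and the step of a 1.9-fold higher number from compound 1 to compound 3 (0.28 log units; within the scatter) lies within the scatter, so no order between these two can be claimed. Compound 2 stands well apart from compound 3, as the two values show.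

Compound 4 `COC(=O)[C@@]1(C)CCC=C2[C@@H]1CC[C@@H](C)[C@]2(C)Cc1c(C)[nH]c2ccc(C(F)(F)F)cc12` differs from compound 3 by trifluoromethyl in place of hydrogen on an aromatic carbon. Among the compounds with values here, two measured steps bear on this. The step of a 5.6-fold lower number from compound 1 to compound 2 (0.75 log units; beyond the scatter) shows that a substituent entering on an aromatic carbon of the six-membered aromatic ring can give a modest lower number. The step of a 1.9-fold higher number from compound 1 to compound 3 (0.28 log units; within the scatter) shows that the methyl already present in compound 3 changes nothing beyond the scatter. Within the data shown here, no compound in the set carries a trifluoromethyl, so the size of the new step cannot be read directly. A modest lower number in this assay is expected for compound 4, a 2.3-fold lower number from compound 3 to compound 4 (0.37 log units; beyond the scatter), with broad uncertainty. The estimate for compound 4 in this assay is 6000 nM, within 1500 nM to 25000 nM.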

Compound 4, concentration for 50% growth inhibition: 15000 nM
Estimate against measurement, compound 4: 2.5-fold (0.40 log units) below, and the stated range covers the measured number.
By their numbers in this assay, from the lowest: compound 2; then compounds 1, 3 and 4 (each within the scatter of the next, the first and the last beyond it).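

In this assay, trifluoromethyl in place of hydrogen on the aromatic carbon gives a 1.1-fold higher number from compound 3 to compound 4 (0.03 log units; within the scatter) and so leaves the two values within the scatter of each other. Substitution at this carbon therefore does not always lower the number: the methoxy step at the same carbon, a 5.6-fold lower number from compound 1 to compound 2 (0.75 log units; beyond the scatter) on a parent without the added methyl, lies beyond the scatter, whereas the trifluoromethyl step does not. No measurement here accounts for the difference between these two steps.

The two steps differ in both the entering group and the parent, so the compounds shown leave open whether methoxy would give the same step with the methyl present, or trifluoromethyl the same step without it. Also open, as far as these compounds go, is how an amine, a carboxylic acid or a hydroxyl group would behave at this carbon.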